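The source may hold more compounds than are shown below. What is called first, only, known or untested is meant among the compounds shown, and "the series" means these compounds.

Measured compounds in a functional assay on HCT-116 cells (Homo sapiens) for cytotoxicity, read by MTT assay, with a stated time of 48 h; a lower number here means a stronger inhibitor, a higher number a weaker inhibitor:
- compound 1 `O=C(/C=C/c1ccc2c(c1)B(O)OC2)c1ccc(Cl)cc1` gives 9300 nM
- compound 2 `O=C(/C=C/c1ccc2c(c1)B(O)OC2)c1ccc([N+](=O)[O-])cc1` gives 9100 nM

Compound 1 holds the higher of the two numbers in this assay, but the gap to compound 2 is small: a 1.0-fold lower number from compound 1 to compound 2 (0.01 log units; within the scatter). The two values are therefore not separated.

Compound 3 `O=C(/C=C/c1ccc2c(c1)B(O)OC2)c1ccc(Cl)c(Cl)c1` is not yet measured. It differs from compound 1 by chloro in place of hydrogen on an aromatic carbon, a second chloro on the ring that already bears one.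

Among the measured compounds shown here, only one step is known, and it exchanges the group that both compounds share rather than adding a further one, so it bears on this change only indirectly; it showed no movement beyond the scatter. Nothing in the shown data points to a large shift in this assay from an added chloro. The step is therefore expected to be modest, if anything toward a lower number: a 1.3-fold lower number from compound 1 to compound 3 (0.12 log units; within the scatter). For compound 3 the estimate in this assay is 7000 nM, with a range of 2500 nM to 20000 nM.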

Compound 3, half-maximal inhibitory concentration: 3200 nM
Estimate against measurement, compound 3: 2.2-fold (0.34 log units) above; the range from low to high includes it.
By their numbers in this assay, from the lowest: compound 3; then compounds 2 and 1 (each within the scatter of the next).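

In this assay, among the compounds shown here, a chloro group added on an aromatic carbon ortho to the existing chloro group and meta to a large group gives a 2.9-fold lower number from compound 1 to compound 3 (0.46 log units; beyond the scatter) and is the first step beyond the scatter. The earlier exchange of that existing chloro for nitro, a 1.0-fold lower number from compound 1 to compound 2 (0.01 log units; within the scatter), stayed within the scatter, so this added position moves the number where that exchange did not. The data shown offer no explanation for this step.

On these data alone, whether the lower number is specific to chloro at this position remains open, since a fluoro, methyl, methoxy or amine group there would separate chloro from other groups. Also open, as far as these compounds go, is whether the new chloro needs the existing one, which a compound carrying chloro at the new position alone would test.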